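The source may hold more compounds than are shown below. What is called first, only, known or untested is meant among the compounds shown, and "the series" means these compounds.

Measured compounds:
Compound 1, `N#CC1=C(N)Oc2c(N)cc3nc4ccccc4nc3c2C12C(=O)N(Cc1cnnn1-c1ccc(Cl)cc1)c1ccccc12`: > 50000 nM
Compound 2, `N#CC1=C(N)Oc2c(N)cc3nc4ccccc4nc3c2C12C(=O)N(Cc1cnnn1-c1cc(Cl)ccc1Cl)c1ccccc12`: 33200 nM

For the measured compounds named here, in a functional assay on MCF7 cells (Homo sapiens) for antiproliferative activity, read by MTT assay, with a stated time of 48 h (on this read-out lower numbers stand for stronger inhibition and higher numbers for weaker inhibition), compound 2 gives 33200 nM, the only actual number among the two measured compounds. Compound 1 gives > 50000 nM, which is a limit of the assay rather than a number; that is the limit of > 50000 nM in this assay, at which 1 of the 2 values shown sits. Going by the values given here, the single measured step, an at least 1.5-fold lower number from compound 1 to compound 2 (0.17 log units; that floor lies within the scatter), swaps one chlorophenyl group for another and does not clearly leave the scatter.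

Compound 3, `Cc1cc(C)c(-n2nncc2CN2C(=O)C3(C(C#N)=C(N)Oc4c(N)cc5nc6ccccc6nc5c43)c3ccccc32)c(C)c1`, differs from compound 2 in one place: 2,4,6-trimethylphenyl in place of 2,5-dichlorophenyl on an aromatic nitrogen. Among the compounds with values here, no measured step here covers a change from chlorine substituents to methyl groups on this ring, so the measured step offers only weak guidance, and it suggests that such swaps on this aromatic nitrogen move the result little. The expected step in this assay is a 1.2-fold higher number from compound 2 to compound 3 (0.08 log units; within the scatter). Compound 3 is therefore estimated at 40000 nM, with a range from 15000 nM to 150000 nM, and a real chance that only a limit is reported.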

Compound 3, half-maximal inhibitory concentration: > 50000 nM
Compound 3 was reported as a limit; the forecaster's own chance of this, stated with the estimate: 40%; at least 1.2-fold (0.09 log units) between middle value and limit.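

The new step, an at least 1.5-fold higher number from compound 2 to compound 3 (0.17 log units; that floor lies within the scatter), shows that 2,4,6-trimethylphenyl, a ring with methyl groups and no chlorine, is not clearly separated from 2,5-dichlorophenyl on this aromatic nitrogen, although the true gap could be larger, as the value of compound 3 is a limit. The step between compound 1 and compound 3 cannot be read: both values are limits. In this assay, most of this small set now sits at one edge of the measurable range: the limit of > 50000 nM in this assay, at which 2 of the 3 values shown sit.

The compounds shown leave open whether any group on this aromatic nitrogen can bring a number clearly lower than that of compound 2, such as a phenyl ring carrying an amine or a carboxylic acid, or a longer alkyl chain in place of the ring. They also leave open whether changes elsewhere on the shared core would matter more.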